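The compounds below may be only part of what the source reports. "The series", "measured", "known", "first", "only" and "open" are said of these compounds alone.

In a functional assay on HepG2 cells (Homo sapiens) for cytotoxicity, read by MTT assay, with a stated time of 48 h (a lower number here means a stronger inhibitor, a higher number a weaker inhibitor), compound 1 (`CC1=NN(C(=O)c2ccc(C)cc2)C(c2cc(Br)cc(Br)c2O)C1`) gives "not active" (no number reported), with no number reported. Compound 2 (`CC1=NN(C(=O)CN2CCC(Cl)CC2)C(c2ccccc2O)C1`) gives 42100 nM and compound 3 (`CC(=O)Oc1ccccc1C1CC(C)=NN1C(=O)CN(C(C)C)C(C)C`) gives 34100 nM, and these two numbers lie within the usual scatter of each other. Compound 4 (`CC(=O)Oc1ccccc1C1CC(C)=NN1C(=O)CN1CCC(C(C)=O)CC1`) keeps the core of compound 3 and makes one change: 4-acetylpiperidin-1-yl in place of diisopropylamino on a saturated chain carbon bound to a carbonyl carbon, with 4-acetylpiperidin-1-yl in place of diisopropylamino on a saturated chain carbon bound to a carbonyl carbon. Within the data shown here, no measured pair shows this swap alone. Compound 2 differs from compound 3 in that group and elsewhere, yet compound 2 gives 42100 nM, which offers only a hint. The expected step of a 1.0-fold higher number from compound 3 to compound 4 (0.01 log units; within the scatter) is none beyond the scatter in this assay, in either direction. The estimated value for compound 4 is 35000 nM, within an expected range from 15000 nM to 80000 nM.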

Compound 4, half-maximal inhibitory concentration: 7800 nM
The estimate for compound 4 lay 4.5-fold (0.65 log units) above the measured number; the measured number lies below the stated range.
By their numbers in this assay, from the lowest: compound 4; then compounds 3 and 2 (each within the scatter of the next).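

In this assay the swap of diisopropylamino for 4-acetylpiperidin-1-yl gives a 4.4-fold lower number from compound 3 to compound 4 (0.64 log units; beyond the scatter) and is the first change shown to isolate this position, on a saturated chain carbon bound to a carbonyl carbon. It shows that the group placed here can move the number beyond the scatter. No measurement shown explains the drop.

On these data alone, the swap brings in the six-membered ring and the acetyl group together, so their separate contributions stay unknown. A plain piperidin-1-yl at this position would be needed to tell them apart.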